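A few compounds are considered here, and "the series" means these few. Any claim that something is new, unique, unknown or untested is made for them only; others in the source may bear on it.

Compound 1 `CCOC(=O)c1sc2nc(SC)nc(-c3cccc(OC)c3)c2c1N`: 1.5%
Compound 2 `CSc1nc(-c2cccc(F)c2)c2c(N)c(C(=O)NC(C)(C)C)sc2n1`: 8.1%
Compound 3 `COc1cccc(-c2nc(SC)nc3sc(C(=O)NCC#N)c(N)c23)c1`: 3.6%

In a functional assay on HEK293 cells for agonist activity at Thyrotropin receptor (Homo sapiens), read by cAMP accumulation (on this read-out higher numbers stand for larger maximal responses and lower numbers for smaller maximal responses), compound 3 gives 3.6%. It differs from compound 1 by a number 2.1 percentage points higher from compound 1 to compound 3 (within the scatter) and from compound 2 by an amount within the scatter, so the three measured compounds cannot be told apart on this read-out.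

Compound 4 `COc1cccc(-c2nc(SC)nc3sc(C(=O)NCCO)c(N)c23)c1` has not been measured. It arises from compound 3 by hydroxymethyl in place of cyano on a saturated chain carbon bound to an amide-type nitrogen. Among the compounds with values here, the only measured step that touches the same carbonyl substituent is a number 2.1 percentage points higher from compound 1 to compound 3 (within the scatter), which lay within the scatter. No step beyond the scatter is therefore expected in this assay from compound 3 to compound 4; the expected step is a number 0.4 percentage points higher from compound 3 to compound 4 (within the scatter). Compound 4 is thus expected to give about 4%, in a range from 0% to 12%.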

Compound 4, largest response reached (reported as efficacy), in percent of the reference or control that the assay uses: 2.9%
Beside the measured number, compound 4's estimate is 1.1 percentage points above it; measured number inside the range.
By their numbers in this assay, from the lowest: compounds 1, 4, 3 and 2 (each within the scatter of the next).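

In this assay, hydroxymethyl in place of cyano on the saturated chain carbon bound to an amide-type nitrogen gives a number 0.7 percentage points lower from compound 3 to compound 4 (within the scatter), so the end of this chain takes a hydrogen-bond donor with no step beyond the scatter. (2-Hydroxyethyl)amino in place of ethoxy on the carbonyl carbon gives a number 1.4 percentage points higher from compound 1 to compound 4 (within the scatter), so all three groups compared at this carbonyl carbon remain within the scatter of one another. Nothing at hand accounts for this flat picture. On these data alone, whether an amine or a carboxylic acid at the end of this chain, or a longer chain, would produce a step beyond the scatter stays open.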